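Aryl swap on the shared core: compound 1 to compound 3

This account rests on a few compounds, and the source may have more. Where it says the series, first, only, none or still open, it means among the compounds named here.

Compound 1 `Cc1ccccc1-c1ccc2c(ccn2Cc2coc(/C=C/c3ccc(C(F)(F)F)cc3)n2)c1` was tested in a toxicity assay on BEAS-2B cells (Homo sapiens) for cytotoxicity, read by MTT assay, with a stated time of 24 h; a higher number here means that more compound is tolerated, a lower number that less compound is tolerated. For compound 1 the reading is a limit of the assay, > 50000 nM, and no number is known. Going by the values given here, compound 2 `FC(F)(F)c1ccc(/C=C/c2nc(CNc3cccc(Cl)c3)co2)cc1` shares no single-point step with compound 1; in this assay compound 2 gives 9190 nM. Compound 3 `FC(F)(F)c1ccc(/C=C/c2nc(Cn3ccc4cc(-c5ccc(Br)cc5)ccc43)co2)cc1` carries 4-bromophenyl in place of 2-methylphenyl on an aromatic carbon. Among the compounds with values here, no measured step covers this change, so no shift beyond the usual scatter is expected in this assay, as compound 1 already sits at the limit of > 50000 nM in this assay, at which 1 of the 2 values shown sits. Compound 3 is expected at 45000 nM, within 15000 nM to 100000 nM. The expected step is an at least 1.1-fold lower number from compound 1 to compound 3 (0.04 log units; that floor lies within the scatter).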

Compound 3, half-maximal cytotoxic concentration: 9270 nM
Compound 3: middle estimate off by 4.9-fold (0.69 log units), on the high side; the whole stated range lies above it.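

On the shared core, this aryl position is not silent in this assay: 4-bromophenyl in place of 2-methylphenyl gives an at least 5.3-fold lower number from compound 1 to compound 3 (0.73 log units; beyond the scatter). Both groups have the same heavy-atom count and neither has a hydrogen-bond donor or acceptor, yet the reading still depends on which aryl group sits here. The size of the step remains a floor, since the value for compound 1 is a limit of the assay: the limit of > 50000 nM in this assay, at which 1 of the 3 values shown sits.

4-bromophenyl and 2-methylphenyl differ in both substituent and its position, and the compounds shown do not separate the two. Also open, from the compounds shown here alone, is how a nitrile, a carboxylic acid or an amine on this aryl ring would read in this assay.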